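Amide in place of amine on the piperidine core

The source may report more compounds than this note shows. Statements on the series, on what has been measured and on what is new or still open speak of the compounds shown alone.

Of the compounds shown here, three have been measured in an ADME assay on HCT-116 cells (Homo sapiens) for cytotoxicity, read by CellTiter-Glo, with a stated time of 72 h; a higher number here means a weaker inhibitor, a lower number a stronger inhibitor.
Compound 1 `Cc1cc(C)c(S(=O)(=O)N2CCC(N3CCC(CCO)CC3)CC2)c(C)c1` gives > 5000 nM, a limit of the assay.
Compound 2 `Cc1cc(C)c(S(=O)(=O)N2CCC(N3CCN(C)CC3)CC2)c(C)c1` gives > 5000 nM, also a limit.
Compound 3 `Cc1cc(C)c(S(=O)(=O)N2CCC(N3CC(C)CC(C)C3)CC2)c(C)c1` gives > 5000 nM, again a limit.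

Compound 3 therefore stands only at a limit, as do the other two, at the limit of > 5000 nM in this assay, at which 3 of the 3 values shown sit. The steps a step that the two limits leave unreadable from compound 1 to compound 2, a step that the two limits leave unreadable from compound 1 to compound 3 and a step that the two limits leave unreadable from compound 2 to compound 3 are unreadable because all three values sit at the limit of > 5000 nM in this assay, at which 3 of the 3 values shown sit. Compound 4 `CCCC(=O)NC1CCN(S(=O)(=O)c2c(C)cc(C)cc2C)CC1` differs from compound 3 by (propylcarbonyl)amino in place of 3,5-dimethylpiperidin-1-yl on a saturated ring carbon. For the measured compounds named here, no measured step bears on this change in a readable way; all that is known is that each replacement on that ring carbon so far has left the value at the limit. Compound 4 is therefore expected to give 8000 nM, with a range from 4000 nM to 20000 nM. The expected step is a step that the limit leaves unreadable from compound 3 to compound 4, most likely again only a limit.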

Compound 4, half-maximal inhibitory concentration: > 5000 nM
Compound 4: only a limit was reported (the forecaster's own chance of this, stated with the estimate: 85%); the middle value does not contradict the limit.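

Compound 4 sits at a limit, as do compound 1, compound 2 and compound 3, so no step among them can be read: the limit of > 5000 nM in this assay, at which 4 of the 4 values shown sit.

The compounds shown leave open whether any group on that saturated ring carbon changes the value in this assay.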